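Aryl urea variation on the shared core

The source may report more compounds than this note shows. Statements on the series, on what has been measured and on what is new or still open speak of the compounds shown alone.

Measured so far:
- compound 1 `COc1cc(Nc2ncnc3c(NC(=O)Nc4ccc(C)c(C)c4)cccc23)cc(OC)c1` gives 8.8 nM in a functional assay on RT-112 cells (Homo sapiens) for antiproliferative activity, read by MTT assay, with a stated time of 72 h; a higher number here means a weaker inhibitor of growth, a lower number a stronger inhibitor of growth
- compound 3 `COc1cc(Nc2ncnc3c(NC(=O)Nc4cccc(C)c4C)cccc23)cc(OC)c1` gives 5910 nM
- compound 2 `COc1cc(Nc2ncnc3c(NC(=O)Nc4ccc(Cl)c(C(F)(F)F)c4)cccc23)cc(OC)c1` reaches only a limit, > 20000 nM

Compound 1 holds the lowest of the two numbers read out; the nearest, compound 3, sits at a 670-fold higher number from compound 1 to compound 3 (2.83 log units; beyond the scatter). For compound 2 the result is a limit and not a number, so the step of an at least 2200-fold higher number from compound 1 to compound 2 (3.35 log units; beyond the scatter) is itself only a bound, as is an at least 3.3-fold lower number from compound 2 to compound 3 (0.52 log units; beyond the scatter).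

Compound 4 `COc1cc(Nc2ncnc3c(NC(=O)Nc4ccc(C(F)(F)F)cc4Cl)cccc23)cc(OC)c1` has not yet been measured. Its difference from compound 1 is 2-chloro-4-(trifluoromethyl)phenyl in place of 3,4-dimethylphenyl on an amide-type nitrogen. Both measured steps from compound 1 bear on it: exchanging the 3,4-dimethylphenyl for a ring bearing chlorine and trifluoromethyl gave an at least 2200-fold higher number from compound 1 to compound 2 (3.35 log units; beyond the scatter), and moving the two methyl groups to the 2,3-dimethylphenyl pattern gave a 670-fold higher number from compound 1 to compound 3 (2.83 log units; beyond the scatter). Going by the values given here, compound 4 combines a chlorine-and-trifluoromethyl ring with yet another substitution pattern, and nothing among the measured compounds points back toward the number of compound 1. A large upward step in this assay is therefore expected, the estimated step being a 1400-fold higher number from compound 1 to compound 4 (3.13 log units; beyond the scatter).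

For compound 4 the expected value is 12000 nM, estimated to lie between 2000 nM and 20000 nM, and a read-out at the limit of > 20000 nM in this assay, at which 1 of the 3 values shown sits, is considered a real possibility.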

Compound 4, concentration for 50% growth inhibition: 1080 nM
Compound 4: the middle estimate sits 11-fold (1.05 log units) above what was measured; the measured number lies below the stated range.
By their numbers in this assay, from the lowest: compound 1; then compound 4; then compound 3. At a limit, above all of these: compound 2.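

Chlorine and trifluoromethyl on the aryl ring of the urea do not in themselves put a compound out of range in this assay: with the 2-chloro-4-(trifluoromethyl)phenyl group on the amide-type nitrogen the step is an at least 18-fold lower number from compound 2 to compound 4 (1.26 log units; beyond the scatter), which is only a bound, as one end of it is a limit and not a number: the limit of > 20000 nM in this assay, at which 1 of the 4 values shown sits. This group also reads better than the 2,3-dimethylphenyl group, with a 5.5-fold lower number from compound 3 to compound 4 (0.74 log units; beyond the scatter), so the dimethyl pair does not outrank the chlorine and trifluoromethyl pair at every substitution pattern shown. Going by these compounds alone, the 3,4-dimethylphenyl group nevertheless keeps a wide lead, with a 120-fold higher number from compound 1 to compound 4 (2.09 log units; beyond the scatter), and compound 1 stays the only compound so far with a number in the low range.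

From the compounds shown here alone, it remains open whether the number of compound 1 needs both methyl groups or only one, and how chlorine alone or trifluoromethyl alone would read on this ring. Also open, going by these compounds, is how a methoxy group or an amine on this ring would read in this assay.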